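Phenyl variation on the ring amine nitrogen: compound 3

The compounds below may be only part of what the source reports. "The series", "measured", "known", "first", "only" and "open" are said of these compounds alone.

Measured so far in a functional assay on the whole organism (strain Swiss CD-1) with Mus musculus as the target, with a stated time of 2 h; a lower number here means that less compound is needed, a higher number that more compound is needed for the effect:
compound 1 `COCC(C(=O)N1CCN(c2ccc(Cl)cc2)CC1)N1C(=O)CCC1=O` gives 45.5 mg/kg
compound 2 `COCC(C(=O)N1CCN(c2cccc(Cl)c2Cl)CC1)N1C(=O)CCC1=O` gives 38 mg/kg

Compound 1 holds the highest of the two numbers; its nearest neighbour is compound 2, with a 1.2-fold lower number from compound 1 to compound 2 (0.08 log units; within the scatter).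

Compound 3 `COCC(C(=O)N1CCN(c2cccc(OC)c2)CC1)N1C(=O)CCC1=O` differs from compound 1 in one place: 3-methoxyphenyl in place of 4-chlorophenyl on an amine nitrogen in a ring. Going by the values given here, the only measured step, a 1.2-fold lower number from compound 1 to compound 2 (0.08 log units; within the scatter), also exchanges the group on that ring nitrogen and stayed within the scatter. Among the compounds with values here, no measured step brings in a methoxyphenyl, so the expectation for compound 3 in this assay rests on that single step alone and is for no change beyond the scatter. Compound 3 is estimated at 50 mg/kg, range 25 mg/kg to 100 mg/kg, which means an expected 1.1-fold higher number from compound 1 to compound 3 (0.04 log units; within the scatter).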

Compound 3, dose for half-maximal effect: > 100 mg/kg
Compound 3: only a limit was reported; the forecaster's own chance of this, stated with the estimate: 15%; at least 2.0-fold (0.30 log units) between middle value and limit.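

On the amine nitrogen in a ring, the choice of aryl group now matters in this assay: 3-methoxyphenyl gives an at least 2.1-fold higher number from compound 1 to compound 3 (0.34 log units; beyond the scatter), and an at least 2.6-fold higher number from compound 2 to compound 3 (0.42 log units; beyond the scatter), whereas the two chlorophenyl compounds stayed within the scatter of each other. This position therefore does not accept every aryl group equally, which the earlier step could not show. The reading for compound 3 is a limit, not a number: the limit of > 100 mg/kg in this assay, at which 1 of the 3 values shown sits.

As far as these compounds go, how an unsubstituted phenyl or a 4-methoxyphenyl on that nitrogen would read remains open. The methoxy group and its placement on the phenyl ring therefore cannot yet be told apart.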